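Swapping the aryl group on the ring nitrogen

The source may hold more compounds than are shown below. What is called first, only, known or untested is meant among the compounds shown, and "the series" means these compounds.

Measured so far:
compound 1 `COc1ccccc1-n1c(Nc2nc(-c3ccccc3)cs2)n[nH]c1=S` — 100 mg/kg
compound 2 `COc1ccc(-n2c(Nc3nc(-c4ccc(Cl)cc4)cs3)n[nH]c2=S)cc1` — 30 mg/kg
compound 3 `COc1ccccc1-n1c(Nc2nc(-c3ccc(Cl)cc3)cs2)n[nH]c1=S` — 100 mg/kg

In a functional assay on the whole organism (strain Swiss albino) for inhibition, with Mus musculus as the target, with a stated time of 0.5 h (a lower number here means that less compound is needed, a higher number that more compound is needed for the effect), compound 3 gives 100 mg/kg, level with compound 1, and these two share the highest number of the three. The only clear movement seen is a 3.3-fold higher number from compound 2 to compound 3 (0.52 log units; beyond the scatter), while no change at the digits printed from compound 1 to compound 3 (within the scatter). Compound 4 `Cc1ccc(-n2c(Nc3nc(-c4ccc(Cl)cc4)cs3)n[nH]c2=S)cc1` has not yet been tested. It differs from compound 3 by 4-methylphenyl in place of 2-methoxyphenyl on an aromatic nitrogen. For the measured compounds named here, the step from compound 2 to compound 3 bears most directly on this change, since it also concerns the aryl group on the aromatic nitrogen, though compound 4 carries 4-methylphenyl rather than 4-methoxyphenyl, and no measured pair shows a methyl in place of a methoxy. On that basis compound 4 is expected to come out with a lower number than compound 3, a step of a 2.5-fold lower number from compound 3 to compound 4 (0.40 log units; beyond the scatter), though the uncertainty is wide. The estimate for compound 4 in this assay is 40 mg/kg, with a range from 15 mg/kg to 100 mg/kg.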

Compound 4, minimum effective dose: 300 mg/kg
Compound 4: middle estimate off by 7.5-fold (0.88 log units), on the low side, outside the stated range (above it).
By their numbers in this assay, from the lowest: compound 2; then compounds 1 and 3 (each within the scatter of the next); then compound 4.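

With the rest of the molecule unchanged, methyl in place of methoxy on the aromatic carbon raises the number (a 10-fold higher number from compound 2 to compound 4 (1.00 log units; beyond the scatter)) in this assay, so this single substituent on the aryl group matters greatly. 4-Methylphenyl also stands apart from 2-methoxyphenyl on the aromatic nitrogen (a 3.0-fold higher number from compound 3 to compound 4 (0.48 log units; beyond the scatter)), which places the three aryl groups in a clear order from the lowest number to the highest: 4-methoxyphenyl, 2-methoxyphenyl, 4-methylphenyl. Nothing available here explains that order.

Going by these compounds, it remains open whether 4-ethoxyphenyl, 4-hydroxyphenyl or plain phenyl on this nitrogen would stay close to 4-methoxyphenyl or fall nearer to 4-methylphenyl. On these data alone, it is also open whether the same order holds without the chloro group, since compound 1 shows only 2-methoxyphenyl on that core.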